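This account rests on a few compounds, and the source may have more. Where it says the series, first, only, none or still open, it means among the compounds named here.

Measured so far in an ADME assay on microsomes from liver (Rattus norvegicus) for metabolic stability; on this read-out higher numbers stand for a longer-lived compound and lower numbers for a shorter-lived compound:
- compound 1 `Nc1nc(NCCNc2ncc(-c3ncc[nH]3)c(-c3ccccc3Cl)n2)ccc1[N+](=O)[O-]`: > 0.5 h, a limit
- compound 2 `Nc1nc(NCCNc2ncc(-c3ncc[nH]3)c(-c3ccc(Br)cc3Cl)n2)ccc1[N+](=O)[O-]`: > 0.5 h, a limit

Compound 2 has no number, only the limit > 0.5 h.

Compound 3 `Nc1nc(NCCNc2ncc(-c3ncc[nH]3)c(-c3ccc(Cl)cc3Br)n2)ccc1[N+](=O)[O-]` has the same atoms as compound 2, joined differently: 2-bromo-4-chlorophenyl in place of 4-bromo-2-chlorophenyl on an aromatic carbon. In words, 2-bromo-4-chlorophenyl stands in place of 4-bromo-2-chlorophenyl on an aromatic carbon.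

For the measured compounds named here, only one measured step bears on this change: a step that the two limits leave unreadable from compound 1 to compound 2. It introduces bromo in place of hydrogen, and its size cannot be read. Going by the values given here, the only other evidence is the limit of > 0.5 h in this assay, at which 2 of the 2 values shown sit. The data therefore give no direction, and no step beyond the scatter is expected in this assay. The expected step is a step that the limit leaves unreadable from compound 2 to compound 3.

For compound 3 the estimate is 0.8 h, with an expected range from 0.4 h to 2 h.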

Compound 3, half-life: > 0.5 h
Compound 3: no number, only a limit; the forecaster's own chance of this, stated with the estimate: 80%; the middle value lies beyond the limit too.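

In this assay compound 3 gives > 0.5 h, which is a limit, so no step from compound 1 or compound 2 to compound 3 can be read: the limit of > 0.5 h in this assay, at which 3 of the 3 values shown sit.

The compounds shown leave open the actual half-lives of all three, and whether swapping 4-bromo-2-chlorophenyl for 2-bromo-4-chlorophenyl changes the half-life at all.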